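The compounds below may be only part of what the source reports. "The series", "measured", "known", "first", "only" and "open" are said of these compounds alone.

Of the compounds shown here, three that share a core have been tested in a functional assay on the whole organism (Tail, strain ICR) with Mus musculus as the target, in the tail flick test, with a stated time of 30 min, at a dose of 25 umol/kg by the oral route; a higher number here means a stronger effect of the compound at the dose given, a lower number a weaker effect. Compound 1, with the structure `CSCC[C@H](NC(=O)CN(c1nc(Cl)nc2[nH]cnc12)C1CC1)C(=O)OCc1ccccc1`, gives 22.2% in this assay. Compound 2, with the structure `C[C@@H](O)[C@H](NC(=O)CN(c1nc(Cl)nc2[nH]cnc12)C1CC1)C(=O)O`, gives 18.6% in this assay, and compound 3, with the structure `CC(C)[C@H](NC(=O)CN(c1ncnc2c1ncn2C1CCCCO1)C1CC1)C(=O)OCc1ccccc1`, gives 21.8% in this assay. Compound 1 carries the highest of the three numbers, yet the gap to compound 3, its nearest neighbour, and the gap to compound 2, its furthest, both lie within the usual scatter of such measurements, so the three cannot be ranked.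

Compound 4, with the structure `O=C(CN(c1nc(Cl)nc2[nH]cnc12)C1CC1)NCC(=O)OCc1ccccc1`, has not yet been measured in this assay. It differs from compound 1 in one place: hydrogen in place of 2-(methylsulfanyl)ethyl on a saturated chain carbon bound to an amide-type nitrogen and a carbonyl carbon. Going by the values given here, no two measured compounds differ in a single place, so there is nothing to show how large such a change tends to be. The three measured numbers sit close together, and so the step is expected to be a number 2.2 percentage points lower from compound 1 to compound 4 (within the scatter), that is, no change beyond the scatter. Compound 4 is therefore estimated at 20%, with a likely range from 10% to 30%.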

Compound 4, a percentage reported as activity, at one dose (the size of the read-out at that dose, not a potency): 18.7%
For compound 4 the middle estimate is 1.3 percentage points above the measured one; the measured number falls inside the stated range.
By their numbers in this assay, from the lowest: compounds 2, 4, 3 and 1 (each within the scatter of the next).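

In this assay, going by these compounds alone, hydrogen in place of 2-(methylsulfanyl)ethyl on a saturated chain carbon bound to an amide-type nitrogen and a carbonyl carbon gives a number 3.5 percentage points lower from compound 1 to compound 4 (within the scatter), the first comparison that isolates a single place. At this one dose, then, the whole chain, sulfur included, can be replaced by hydrogen without a change beyond the scatter, so this result gives no sign that the chain is needed for the read-out. No separate measurement bears on this result.

As far as these compounds go, what remains open is whether a different group at this place, such as a benzyl group, a chain ending in an amine or a chain ending in a carboxylic acid, would shift the number beyond the scatter. A single dose also leaves potency unresolved, since a difference might appear at other doses.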